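This account rests on a few compounds, and the source may have more. Where it says the series, first, only, none or still open, it means among the compounds named here.

Of the compounds shown here, two have been measured in a functional assay for antagonist activity at Neuropeptides B/W receptor type 1 (Homo sapiens), read by cAMP accumulation; a lower number here means a stronger inhibitor, a higher number a weaker inhibitor. Compound 1 `FC(F)(F)c1ccc2[nH]c(-c3ccccc3)nc2c1` gives 1200 nM there, the lowest of the two numbers. Compound 2 `O=[N+]([O-])c1ccc2[nH]c(-c3ccccc3N3CCCC3)nc2c1` gives 6770 nM in this assay, a higher number that lies beyond the usual scatter; the two structures differ in more than one place, so no single change can be read from their values.

Compound 3 `FC(F)(F)c1ccc2[nH]c(-c3ccc(-c4c[nH]nc4C(F)(F)F)cc3)nc2c1` has not yet been measured in this assay. It differs from compound 1 in one place: 3-(trifluoromethyl)-1H-pyrazol-4-yl in place of hydrogen on an aromatic carbon. Among the compounds with values here, the new group carries a second aromatic ring out from the shared core, and nothing among the measured compounds shows what such an extension does here. Without any measured step that parallels this change, the expectation rests on the value of compound 1 alone; a modest shift toward a lower number seems as likely as no change beyond the scatter. Compound 3 is therefore expected to give about 600 nM in this assay, most probably between 150 nM and 2500 nM, which would mean an estimated step of a 2.0-fold lower number from compound 1 to compound 3 (0.30 log units; within the scatter).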

Compound 3, half-maximal inhibitory concentration: 1200 nM
Beside the measured number, compound 3's estimate is 2.0-fold (0.30 log units) below it, and the stated range covers the measured number.
By their numbers in this assay, from the lowest: compounds 1 and 3 (each within the scatter of the next); then compound 2.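

In this assay, placing 3-(trifluoromethyl)-1H-pyrazol-4-yl in place of hydrogen on the aromatic carbon para to a large group gives no change at the digits printed from compound 1 to compound 3 (within the scatter). The earlier compounds shown here said nothing about this position, and this single step now shows that it can carry a group of 9 heavy atoms, including a second aromatic ring, while the number stays within the scatter of the unsubstituted parent. Nothing available here explains why so large an addition leaves the value in place.

One step at one position cannot show whether this place is generally insensitive to what it carries or whether this group simply happens to give a similar value, so a smaller group such as methyl, or a charged one such as a carboxylic acid or an amine, could still give a clearly different number there. Going by these compounds, it also remains open what the trifluoromethyl on the new ring contributes, a question that a plain 1H-pyrazol-4-yl at the same place could answer.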